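The source may report more compounds than this note shows. Statements on the series, on what has been measured and on what is new or still open speak of the compounds shown alone.

Working notes on the series.

Compound 3 `C=C1CN(C)N(c2ccc(C)cc2)C1=O` gives 90100 nM in a functional assay on NALM-6 cells (Homo sapiens) for inhibition, read by MTT assay, with a stated time of 48 h (a higher number here means a weaker inhibitor, a lower number a stronger inhibitor), the highest of the three numbers seen so far. Its nearest neighbour is compound 1 `C=C1CN(C)N(c2ccc(Br)cc2)C1=O`, which in this assay gives 62000 nM; the furthest is compound 2 `C=C1C(=O)N(c2ccccc2)N(C)C1c1ccccc1`, which gives 24400 nM in this assay but differs from compound 3 at more than one place, so no single step can be read from that pair.

Compound 4 `C=C1CN(C)N(c2ccccc2)C1=O` has not been measured. It differs from compound 3 by hydrogen in place of methyl on an aromatic carbon, the place being para to a group of 8 heavy atoms. Among the measured compounds shown here, the only measured step that touches this position is a 1.5-fold higher number from compound 1 to compound 3 (0.16 log units; within the scatter), which stayed within the scatter. Nothing else in the data speaks to removing the substituent at this carbon altogether.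

Given that the swap at this carbon changed little, the step of a 1.3-fold lower number from compound 3 to compound 4 (0.11 log units; within the scatter) is expected to stay within the scatter of this assay. Compound 4 is therefore estimated at 70000 nM, with a range of 30000 nM to 160000 nM.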

Compound 4, half-maximal inhibitory concentration: 56000 nM
Compound 4: middle estimate off by 1.3-fold (0.10 log units), on the high side; the range from low to high includes it.
By their numbers in this assay, from the lowest: compound 2; then compounds 4, 1 and 3 (each within the scatter of the next).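

In this assay the aromatic carbon proves tolerant of losing its substituent altogether: hydrogen in place of methyl gives a 1.6-fold lower number from compound 3 to compound 4 (0.21 log units; within the scatter) and hydrogen in place of bromo gives a 1.1-fold lower number from compound 1 to compound 4 (0.04 log units; within the scatter) so hydrogen, methyl and bromo at this carbon cannot be told apart. The saturated ring carbon behaves differently, since compound 4 links compound 2 to the series through one change, and hydrogen in place of phenyl there gives a 2.3-fold higher number from compound 2 to compound 4 (0.36 log units; beyond the scatter) as a modest step beyond the scatter. No measurement at hand offers an explanation for either result.

From the compounds shown here alone, whether an amine or a carboxylic acid on the aromatic carbon would also stay within the scatter remains open. Also open, going by these compounds, is whether methyl or a longer chain on the saturated ring carbon would match phenyl there.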